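An oxadiazolylmethyl group in place of the primary amide

This account rests on a few compounds, and the source may have more. Where it says the series, first, only, none or still open, it means among the compounds named here.

Compound 1 `CN(C)[C@H]1C[C@H](c2c[nH]c3ccc(C(N)=O)cc32)C1` is the stronger of the two compounds measured in an assay on CHO-K1 cells for binding affinity to 5-hydroxytryptamine receptor 1D (Homo sapiens) (a lower number here means a stronger inhibitor, a higher number a weaker inhibitor), where compound 1 gives 14.8 nM. Going by the values given here, compound 2 `CN(C)[C@H]1C[C@H](c2c[nH]c3ccc(C(=O)NCc4ccccc4)cc32)C1` gives 141 nM in this assay, and the step of a 9.5-fold higher number from compound 1 to compound 2 (0.98 log units; beyond the scatter) is the only change measured so far on this part of the shared core. Compound 3 `Cc1noc(Cc2ccc3[nH]cc([C@H]4C[C@H](N(C)C)C4)c3c2)n1` carries a different exchange on the same aromatic carbon: (3-methyl-1,2,4-oxadiazol-5-yl)methyl in place of carbamoyl on an aromatic carbon. Among the compounds with values here, the step from compound 1 to compound 2 shows that benzyl in place of the amide hydrogen costs affinity, but compound 3 replaces the whole carbamoyl rather than extending it, and no measured step covers such an exchange. The expected step from compound 1 to compound 3 in this assay is therefore small, estimated as a 1.2-fold lower number from compound 1 to compound 3 (0.09 log units; within the scatter). Compound 3 is accordingly expected to give 12 nM in this assay, with a range from 3 nM to 50 nM.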

Compound 3, half-maximal inhibitory concentration: 933 nM
For compound 3 the middle estimate is 78-fold (1.89 log units) below the measured one, outside the stated range (above it).
By their numbers in this assay, from the lowest: compound 1; then compound 2; then compound 3.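

In this assay, putting (3-methyl-1,2,4-oxadiazol-5-yl)methyl in place of carbamoyl on this aromatic carbon gives a 63-fold higher number from compound 1 to compound 3 (1.80 log units; beyond the scatter), so this position does not take this exchange without a large loss of affinity. Compound 2 had shown only that benzyl on the amide nitrogen, with the carbonyl kept, gives a 9.5-fold higher number from compound 1 to compound 2 (0.98 log units; beyond the scatter), whereas compound 3 shows that replacing the whole carbamoyl can cost considerably more. No supporting data are available to explain the size of this step.

The compounds shown leave open whether the loss in compound 3 follows from the oxadiazole ring, its methyl group or the carbon linking it to the core, as all three enter together. They also leave open how a nitrile, a sulfonamide or a carboxylic acid would fare on this same aromatic carbon.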